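The compounds below may be only part of what the source reports. "The series", "measured", "known", "first", "only" and "open" are said of these compounds alone.

Going by the values given here, compound 3 `Cc1csc(NC(=O)Cn2cc(-c3cccc(N)c3)nn2)n1` stands lowest of the three numbers measured so far in a functional assay on BMDM cells (Mus musculus, strain C57BL/6) for inhibition, with a stated time of 2 days; a higher number here means a weaker inhibitor, a lower number a stronger inhibitor; in that assay compound 3 gives 250 nM. Its nearest neighbour is compound 2 `O=C(Cn1cc(-c2ccc([N+](=O)[O-])cc2)nn1)Nc1nccs1`, which in this assay gives 1040 nM, and the furthest is compound 1 `Nc1cccc(-c2cn(CC(=O)Nc3nccs3)nn2)c1`, which in this assay gives 1270 nM. Among the compounds with values here, the only step between two measured compounds that differ in a single place is a 5.1-fold lower number from compound 1 to compound 3 (0.71 log units; beyond the scatter), and that change sits on the shared core, not at the place now in question.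

Compound 4 `Cc1csc(NC(=O)Cn2cc(-c3ccc(F)cc3)nn2)n1` has not yet been measured. It differs from compound 3 in one place: 4-fluorophenyl in place of 3-aminophenyl on an aromatic carbon. Within the data shown here, no measured step covers this exchange directly. The closest guide is the pair of compound 1 and compound 2, which differ only in the group carried on the six-membered aromatic ring of carbon only; their two values lie within the scatter of one another, so they show no difference that can be trusted. On that basis only a small step is expected, with no clear direction. Compound 4 is therefore estimated at 350 nM, with a range from 120 nM to 1000 nM. That estimate corresponds to an expected step of a 1.4-fold higher number from compound 3 to compound 4 (0.15 log units; within the scatter).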

Compound 4, half-maximal inhibitory concentration: 250 nM
Beside the measured number, compound 4's estimate is 1.4-fold (0.15 log units) above it; measured number inside the range.
By their numbers in this assay, from the lowest: compounds 3 and 4 (each within the scatter of the next); then compounds 2 and 1 (each within the scatter of the next).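

In this assay, putting 4-fluorophenyl in place of 3-aminophenyl on the aromatic carbon of the five-membered ring gives no change at the digits printed from compound 3 to compound 4 (within the scatter). On this methyl-bearing core, then, this one pair shows that the number can hold without the amino group: the group that leaves has 1 hydrogen-bond donor and 1 hydrogen-bond acceptor, the group that enters has neither, and the six-membered aromatic ring of carbon only stays in both. Nothing available explains why the two groups give matching numbers.

This exchange alters two things at once, the substituent on the phenyl ring and where it sits on that ring, so the matching numbers cannot be credited to either alone; 3-fluorophenyl or 4-aminophenyl would pull the two apart. From the compounds shown here alone, it also stays open whether this position needs an aromatic ring at all, which a saturated group such as cyclohexyl would test, and whether a carboxylic acid on the phenyl ring would leave the number unchanged as well.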